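The compounds below may be only part of what the source reports. "The series", "measured", "known", "first", "only" and "open" are said of these compounds alone.

Of the compounds shown here, three have been measured in a functional assay for antagonist activity at transient receptor potential cation channel subfamily V member 1 (Rattus norvegicus), read by FLIPR; on this read-out lower numbers stand for lower potency and higher numbers for higher potency (the scale is a negative logarithm). Compound 1, `O=C(Nc1ccccc1Br)N[C@@H]1CCN(c2cccc(C(F)(F)F)n2)C1`, gives 7.2 in this assay. Compound 2, `Cc1ccc2c(c1)CCN2CCNC(=O)Nc1ccccc1Br`, gives 7.3. Compound 3, `O=C(Nc1ccccc1Br)N[C@@H]1CCN(c2cc(C(F)(F)F)ccn2)C1`, gives 6.9. The number for compound 2 is the top of the three, although compound 1 sits within the usual scatter of it, a difference too small to rank the two; compound 3 lies beyond the scatter below compound 2.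

Compound 4, `O=C(NCCN1CCc2ccccc21)Nc1ccccc1Br`, has not yet been measured. It differs from compound 2 in one place: hydrogen in place of methyl on an aromatic carbon. The methyl is simply absent, and the rest of the structure is unchanged. Within the data shown here, no pair of measured compounds shows this kind of change, so the data give no direct guide to its effect. With only the removal of one carbon on the fused ring system, a change no larger than the scatter is expected, leaning slightly downward, as a number 0.20 log units lower from compound 2 to compound 4 (within the scatter). Compound 4 is therefore estimated to give 7.1 in this assay, with a range from 6.6 to 7.6.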

Compound 4, negative logarithm of the antagonist equilibrium constant: 6.8
Compound 4: the middle estimate sits 0.30 log units above what was measured, within the range that was stated.
By their numbers in this assay, from the lowest: compounds 4, 3, 1 and 2 (each within the scatter of the next, the first and the last beyond it).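

In this assay, among these compounds, the change of hydrogen in place of methyl on an aromatic carbon is a number 0.50 log units lower from compound 2 to compound 4 (beyond the scatter) and gives the first step in this set between two compounds that differ in one place. It shows that this single carbon, on the six-membered aromatic ring of the fused system, is enough to move the number beyond the usual scatter, with the methyl compound on the higher side. Nothing measured here accounts for the step, so it stands as an observation only.

On these data alone, whether an ethyl group, a methoxy group or a chlorine atom at this position would match the methyl, exceed it or fall short remains open. Also open, as far as these compounds go, is how a methyl would behave on the other carbons of that ring.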